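The source may hold more compounds than are shown below. What is called first, only, known or untested is meant among the compounds shown, and "the series" means these compounds.

Measured compounds:
- compound 1, `CCCCc1nc(C(C)C)c(CC(=O)OCC(F)(F)F)c(=O)n1Cc1ccc(-c2ccccc2-c2noc(=O)[nH]2)cc1` – in an ADME assay on microsomes from liver (Mus musculus) for metabolic stability, with a stated time of 30 min (a higher number here means that more of the compound is left, a lower number that less of the compound is left), compound 1 gives "not determined" (no result reported)
- compound 2, `CCCCCOC(=O)Cc1c(C(C)C)nc(CCCC)n(Cc2ccc(-c3ccccc3-c3noc(=O)[nH]3)cc2)c1=O` – 19.7%

Within the data shown here, compound 2 carries the only number in this assay; compound 1 was run without a reported result, so nothing can be said of its standing. Among the measured compounds shown here, with a single value there is no step between measured compounds to lean on, and no pair tells how an ester substituent moves the read-out.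

Compound 3, `CCCCc1nc(C(C)C)c(CC(=O)OC2CCCCC2)c(=O)n1Cc1ccc(-c2ccccc2-c2noc(=O)[nH]2)cc1`, differs from compound 2 by cyclohexyl in place of pentyl on an oxygen next to a carbonyl group. The leaving and entering groups are close in size and alike in donor and acceptor count; the change does not touch the rest of the molecule.

For compound 3 the step of a number 2.3 percentage points higher from compound 2 to compound 3 (within the scatter) is expected to stay within the usual scatter, with no direction favoured. The expected value for compound 3 is 22%, in the range 8% to 42%.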

Compound 3, percent of the compound remaining: 14.6%
The estimate for compound 3 lay 7.4 percentage points above the measured number; the measured number falls inside the stated range.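

In this assay, among these compounds, cyclohexyl in place of pentyl on an oxygen next to a carbonyl group gives a number 5.1 percentage points lower from compound 2 to compound 3 (within the scatter), the first step that can be read at this position. An open chain and a six-membered non-aromatic ring of carbon only are therefore not told apart here, and the read-out stays low with either group: compound 2 gives 19.7% and compound 3 gives 14.6%. No measurement at hand speaks to the reason for this result.

A single step within the scatter sets no trend for this position, and the trifluoroethyl ester of compound 1 adds no comparison. Open, as far as these compounds go, is how this assay responds to a carboxylic acid or an amide in place of these esters, or to a tert-butyl group or a longer chain on the same oxygen.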